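This account rests on a few compounds, and the source may have more. Where it says the series, first, only, none or still open, it means among the compounds named here.

Compounds measured so far: compound 1 `COc1cccc(OCC(=O)Nc2cccc(NC(=O)c3ccc(N(C)C)cc3)c2)c1`; compound 2 `COc1ccc(OCC(=O)Nc2cccc(NC(=O)c3ccc(N(C)C)cc3)c2)cc1OC`; compound 3 `CCc1ccc(C(=O)Nc2cccc(NC(=O)COc3ccc4c(=O)ccoc4c3)c2)cc1`.

In an assay on isolated protein for inhibition of Rho-associated protein kinase 1 (Homo sapiens), read by scintillation counting, radiometric assay and 33P incorporation, with a stated time of 40 min, in the presence of a further agent that is not named here (a lower number here means a stronger inhibitor, a higher number a weaker inhibitor), compound 1 gives only a limit, > 10000 nM. Compound 2 likewise returns a limit in this assay, > 10000 nM. Within the data shown here, compound 3 in this assay gives 235 nM, the only actual number among the three values; the other two sit at the limit of > 10000 nM in this assay, at which 2 of the 3 values shown sit. Among the measured compounds shown here, the one step between measured compounds that differ in a single place, a step that the two limits leave unreadable from compound 1 to compound 2, cannot be sized because both its ends rest at the limit of > 10000 nM in this assay, at which 2 of the 3 values shown sit.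

Compound 4 `O=C(COc1ccc2c(=O)ccoc2c1)Nc1cccc(NC(=O)c2cccc([N+](=O)[O-])c2)c1` differs from compound 3 by 3-nitrophenyl in place of 4-ethylphenyl on a carbonyl carbon. For the measured compounds named here, no measured step touches this part of the molecule; the single measured step concerns a methoxy group elsewhere and is unreadable, so nothing measured sets the direction or size of the change. Going by the values given here, the only anchor is the value of compound 3, and the expectation therefore carries a wide range. Compound 4 is expected to give 600 nM in this assay, with a likely range from 120 nM to 4000 nM. The step this expectation implies, a 2.6-fold higher number from compound 3 to compound 4 (0.41 log units; beyond the scatter), is estimated as a moderate weakening that may well fall within the usual scatter.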

Compound 4, half-maximal inhibitory concentration: 528 nM
Compound 4: the middle estimate sits 1.1-fold (0.06 log units) above what was measured; low and high end bracket the measured number.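

In this assay, among these compounds, the exchange on the carbonyl carbon gives the first readable step: a 2.2-fold higher number from compound 3 to compound 4 (0.35 log units; beyond the scatter). This shows that the aryl group at this position affects the read-out, and the change is beyond the scatter but modest. With the ethyl-bearing ring replaced by a nitro-bearing one, compound 4 still returns a number and not a limit, which shows that this position accepts more than one kind of substituted phenyl.

Among the compounds shown here, the single step alters both the substituent and its ring position, leaving their contributions unseparated; 4-nitrophenyl, 3-ethylphenyl or 3-aminophenyl at this carbonyl carbon would address that. The step from compound 1 to compound 2 still cannot be read, and the methoxy change remains unsized: the limit of > 10000 nM in this assay, at which 2 of the 4 values shown sit.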